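The source may report more compounds than this note shows. Statements on the series, on what has been measured and on what is new or still open speak of the compounds shown alone.

Compound 1 `c1cc([C@H]2CC[C@]3(CC2)OOC2(O3)C3CC4CC(C3)CC2C4)ccc1OCC1CCNCC1`: < 7 mL.min-1.g-1
Compound 2 `N[C@H]1CC[C@@H](Oc2ccc([C@H]3CC[C@]4(CC3)OOC3(O4)C4CC5CC(C4)CC3C5)cc2)CC1`: < 7 mL.min-1.g-1

In an ADME assay on microsomes from liver (Homo sapiens) for metabolic stability, read by LC-MS, tested at 1 uM (on this read-out lower numbers stand for slow clearance and higher numbers for fast clearance), compound 2 gives < 7 mL.min-1.g-1, which is a limit of the assay and not a number. Compound 1 gives < 7 mL.min-1.g-1, which is also a limit. The measurements so far come down to the limit of < 7 mL.min-1.g-1 in this assay, at which 2 of the 2 values shown sit, so compound 2 has no exact place on the scale.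

Compound 3 `CC1(C)CC(O)(COc2ccc([C@H]3CC[C@]4(CC3)OOC3(O4)C4CC5CC(C4)CC3C5)cc2)CC(C)(C)N1`, not yet measured, carries (4-hydroxy-2,2,6,6-tetramethylpiperidin-4-yl)methyl in place of 4-aminocyclohexyl on an oxygen on an aromatic ring. Among the measured compounds shown here, the only measured step that bears on this change is a step that the two limits leave unreadable from compound 1 to compound 2, also on an oxygen on an aromatic ring, and it offers no size to carry over. In this assay no change beyond the scatter is therefore expected, and the estimated step is a step that the limit leaves unreadable from compound 2 to compound 3, starting from compound 2 at < 7 mL.min-1.g-1. For compound 3 the estimated value is 6 mL.min-1.g-1, expected to lie between 3 mL.min-1.g-1 and 14 mL.min-1.g-1.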

Compound 3, intrinsic clearance in microsomes: 14 mL.min-1.g-1
Compound 3: middle estimate off by 2.3-fold (0.37 log units), on the low side; measured number inside the range.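

In this assay, compound 3 is the only compound shown with an exact number, so this position on an oxygen on an aromatic ring now gives a readable floor for a step: an at least 2.0-fold higher number from compound 2 to compound 3 (0.30 log units; that floor lies within the scatter). The change from piperidin-4-yl to 4-hydroxy-2,2,6,6-tetramethylpiperidin-4-yl gives a matching floor: an at least 2.0-fold higher number from compound 1 to compound 3 (0.30 log units; that floor lies within the scatter). These floors do not show a change beyond the scatter, and the true size of each step stays unknown because the values of compound 1 and compound 2 are limits: the limit of < 7 mL.min-1.g-1 in this assay, at which 2 of the 3 values shown sit.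

Going by these compounds, in compound 3 the hydroxyl and the four methyl groups enter together, so their separate contributions remain open. A 4-hydroxypiperidin-4-yl group without the methyl groups, or a 2,2,6,6-tetramethylpiperidin-4-yl group without the hydroxyl, would tell them apart.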